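The compounds below may be only part of what the source reports. "The series", "measured", "known", "first", "only" and "open" are said of these compounds alone.

Compound 1, `CNc1nc(NCCCN(C)C)c2sc(-c3ccc(C(F)(F)F)cc3)cc2n1`, is the starting point of this comparison. In an ADME assay (liver) for metabolic stability, with Liver microsome (Homo sapiens) as the target, read by LC-MS, using microsomes, tested at 1 uM (on this read-out lower numbers stand for slow clearance and higher numbers for fast clearance), compound 1 gives 14 uL/min, the higher of the two numbers reported, though its nearest neighbour, compound 3, `CNc1nc(NCCCN(C)C)c2sc(-c3ccc(C(F)(F)F)cc3Cl)cc2n1`, sits within the usual scatter of it: in this assay compound 3 gives 13 uL/min, and the step of a 1.1-fold lower number from compound 1 to compound 3 (0.03 log units; within the scatter) corresponds to a chloro in place of hydrogen on an aromatic carbon. Compound 2, `CNc1nc(NCCCN(C)C)c2sc(-c3cncnc3)cc2n1`, returns a limit rather than a number in this assay, namely < 17 uL/min. That limit is the limit of < 17 uL/min in this assay, at which 1 of the 3 values shown sits.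

The compound not yet measured is compound 4, `CNc1nc(NCCCN(C)C)c2sc(-c3ccc(S(C)(=O)=O)cc3)cc2n1`. It differs from compound 1 in one place: methylsulfonyl in place of trifluoromethyl on an aromatic carbon. For the measured compounds named here, no measured step involves a methylsulfonyl group or the loss of a trifluoromethyl group, so none bears directly on this change. Going by the values given here, the only step available, from compound 1 to compound 3, was within the scatter, and every number reported so far is low. On that basis no step beyond the scatter is expected, and the change from compound 1 to compound 4 is estimated as a 1.2-fold lower number from compound 1 to compound 4 (0.07 log units; within the scatter). Compound 4 is accordingly expected to give 12 uL/min in this assay, with a likely range from 6 uL/min to 24 uL/min.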

Compound 4, intrinsic clearance in a liver preparation (reported as CLH), per the amount of preparation that the assay uses: 15 uL/min
For compound 4 the middle estimate is 1.3-fold (0.10 log units) below the measured one, within the range that was stated.
By their numbers in this assay, from the lowest: compounds 3, 1 and 4 (each within the scatter of the next).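

In this assay, the step of a 1.1-fold higher number from compound 1 to compound 4 (0.03 log units; within the scatter) shows that this position, on an aromatic carbon of a six-membered aromatic ring of carbon only, can carry methylsulfonyl in place of trifluoromethyl with no difference beyond the scatter. The one readable step before it, a 1.1-fold lower number from compound 1 to compound 3 (0.03 log units; within the scatter), was a chloro in place of hydrogen that left the trifluoromethyl where it stood, whereas compound 4 is the first shown in which that group itself is exchanged, with hydrogen-bond acceptors entering where trifluoromethyl has none. Nothing in the data shown bears on why this exchange stays within the scatter.

As far as these compounds go, whether a carboxylic acid, a nitrile or a longer chain at this same position would also stay within the scatter remains open, as does the effect of any change to the dimethylamino chain or the methylamino group, which all the compounds share. Compound 2 gives a limit of the assay, < 17 uL/min, and not a number, so its steps to the other compounds cannot be read.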